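Bromo for Methyl on a Scaffold Without Measurable Cytotoxicity

The source may report more compounds than this note shows. Statements on the series, on what has been measured and on what is new or still open speak of the compounds shown alone.

Compound 1 `Cc1ccsc1C(c1c(C)noc1C)N1CCN(c2ncnc3c2cnn3-c2ccccc2)CC1` gives > 25000 nM in a functional assay on cells (Rhabdomyosarcoma cell, Homo sapiens) for cytotoxicity (on this read-out higher numbers stand for weaker inhibition and lower numbers for stronger inhibition), a limit of the assay rather than a number.
Compound 2 `Cc1ccsc1C(c1ccccn1)N1CCN(c2ncnc3c2cnn3-c2ccccc2)CC1` gives > 25000 nM in this assay, again a limit.
Compound 3 `Cc1ccccc1C(c1sccc1C)N1CCN(c2ncnc3c2cnn3-c2ccccc2)CC1` gives > 25000 nM in this assay, also a limit.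

Compound 3 therefore stands only at a limit, and so do the two others: the limit of > 25000 nM in this assay, at which 3 of the 3 values shown sit. The three measured steps, a step that the two limits leave unreadable from compound 1 to compound 2, a step that the two limits leave unreadable from compound 1 to compound 3 and a step that the two limits leave unreadable from compound 2 to compound 3, show no readable size, so no direction can be taken from them.

Compound 4 `Cc1ccsc1C(c1ccccc1Br)N1CCN(c2ncnc3c2cnn3-c2ccccc2)CC1` differs from compound 3 by bromo in place of methyl on an aromatic carbon. Among the measured compounds shown here, none of the measured steps bears on this change in a readable way; what they show is that changes of the group on the saturated chain carbon have not moved any compound off the limit in this assay. The step from compound 3 to compound 4 is therefore expected to be a step that the limit leaves unreadable from compound 3 to compound 4, with no reading of direction beyond the scatter.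

Compound 4 is estimated at 30000 nM in this assay, within a range from 10000 nM to 100000 nM, most likely reported again as a limit.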

Compound 4, half-maximal inhibitory concentration: > 25000 nM
Compound 4: a limit, no number; the forecaster's own chance of this, stated with the estimate: 85%; the middle value is on the limit's open side.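

Compound 4 gives > 25000 nM in this assay, which is a limit and not a number. Its steps from compound 1, compound 2 and compound 3 cannot be read, since all four compounds stand at one limit: the limit of > 25000 nM in this assay, at which 4 of the 4 values shown sit. These compounds leave open how strongly any of them acts on these cells, and which change, if any, would yield a measurable value.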